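The source may hold more compounds than are shown below. What is called first, only, known or untested is meant among the compounds shown, and "the series" means these compounds.

In an assay on LX2 cells for inhibition of COL1A1 promoter (Homo sapiens), read by a luciferase reporter, with a stated time of 24 h, tested at 50 uM (a higher number here means a stronger effect of the compound at the concentration tested, a lower number a weaker effect), compound 1 `CC[N+]1(CCCCCCCOc2ccc(-n3cc(C(=O)Nc4cc(F)cc(F)c4)c(=O)c4ccc(N(C)C)nc43)cc2C)CCCCC1` gives 53.4% and compound 2 `CC[N+]1(CCCCCCCOc2ccc(-n3cc(C(=O)Nc4cc(F)cc(F)c4)c(=O)c4ccc(N(C)C)nc43)cc2Cl)CCCCC1` gives 50.4%. The two differ in one place: chloro in place of methyl on an aromatic carbon. The resulting step, a number 3 percentage points lower from compound 1 to compound 2 (within the scatter), is small. Compound 3 `CC[N+]1(CCCCCCCOc2cc(-n3cc(C(=O)Nc4cc(F)cc(F)c4)c(=O)c4ccc(N(C)C)nc43)ccc2C)CCCC1` gives 81.4% in this assay, the highest of the three measured values, and its difference from the core of compound 1 is not broken down here. Compound 4 `CC[N+]1(CCCCCCCOc2cc(-n3cc(C(=O)Nc4cc(F)cc(F)c4)c(=O)c4ccc(N(C)C)nc43)ccc2Cl)CCCC1` has not yet been measured in this assay. It differs from compound 3 in one place: chloro in place of methyl on an aromatic carbon. This is the same kind of change as that from compound 1 to compound 2, though not the same, since the place is para to a large group in compound 4 but meta to a large group in compound 2. As the step from compound 1 to compound 2 was a number 3 percentage points lower from compound 1 to compound 2 (within the scatter), a similarly small step is expected here, a number 3.4 percentage points lower from compound 3 to compound 4 (within the scatter), resting on the value of compound 3, 81.4%. Compound 4 is therefore estimated to give about 78% in this assay, expected to lie between 62% and 90%.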

Compound 4, a percentage reported as inhibition, at one concentration (the size of the read-out at that concentration, not a potency): 96.4%
Compound 4: the middle estimate sits 18.4 percentage points below what was measured, and the stated range ends below it.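

In this assay, chloro in place of methyl on an aromatic carbon gives a number 15 percentage points higher from compound 3 to compound 4 (beyond the scatter), so the effect of this change did not carry over intact from one core to the other: the same change on two cores in this assay, a number 3 percentage points lower (within the scatter) from compound 1 to compound 2 and a number 15 percentage points higher (beyond the scatter) from compound 3 to compound 4, 18 percentage points apart, beyond the scatter of two such steps

This shows that, in this series, the step measured on one core cannot simply be transferred to the other. It does not show which structural difference between the core of compound 1 and the core of compound 3 separates the two steps, since those cores differ in more than one place, and a single pair on each core establishes no general rule. The read-out is also taken at one concentration, so neither step describes a change in potency.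

From the compounds shown here alone, it remains open how a plain hydrogen, a fluoro, a methoxy or a trifluoromethyl group on the same aromatic carbon would behave on either core. For the compounds shown here, also open is whether the two steps would stay apart with a shorter or longer chain in place of the one these compounds share.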